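Swapping oxetan-3-yl for oxan-4-yl at the assay limit

The source may report more compounds than this note shows. Statements on the series, on what has been measured and on what is new or still open speak of the compounds shown alone.

Measured so far in a toxicity assay on HT-29 cells (Homo sapiens) for cytotoxicity (a lower number here means that less compound is tolerated, a higher number that more compound is tolerated), each value being a limit and not a number:
Compound 1 `CN1C(=S)[C@@H](NC(=O)c2nc(Cc3ccccc3)n(CCC(F)(F)F)n2)COc2ccccc21`: > 100000 nM
Compound 2 `CN1C(=S)[C@@H](NC(=O)c2nc(Cc3ccccc3)n(CCCC#N)n2)COc2ccccc21`: > 100000 nM
Compound 3 `CN1C(=S)[C@@H](NC(=O)c2nc(Cc3ccccc3)n(C3COC3)n2)COc2ccccc21`: > 100000 nM

Compound 3 stands at > 100000 nM, which is a limit and not a number. Among the compounds with values here, the same holds for the other two measured compounds, so the series so far shows only (the limit of > 100000 nM in this assay, at which 3 of the 3 values shown sit). No number therefore exists from which to read a trend.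

The next structure is compound 4 `CN1C(=S)[C@@H](NC(=O)c2nc(Cc3ccccc3)n(C3CCOCC3)n2)COc2ccccc21`. It carries oxan-4-yl in place of oxetan-3-yl on an aromatic nitrogen.

The measured steps closest to this one change the group on that same nitrogen. They are a step that the two limits leave unreadable from compound 1 to compound 3 and a step that the two limits leave unreadable from compound 2 to compound 3. Within the data shown here, neither has a size that can be read, so they give no direction for this assay and say only that these different groups all ended at the limit. The remaining step, a step that the two limits leave unreadable from compound 1 to compound 2, is just as unreadable.

The estimated change is a number no higher from compound 3 to compound 4 (the limit leaves the size open), so no step beyond the usual scatter is expected. Compound 4 is also expected to be reported most probably as a limit rather than a number. For compound 4 the estimated value is 100000 nM, with an expected range from 40000 nM to 200000 nM.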

Compound 4, half-maximal cytotoxic concentration: > 100000 nM
Compound 4: only a limit was reported; the forecaster's own chance of this, stated with the estimate: 90%; the middle value sits exactly at the limit.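

In this assay compound 4 gives > 100000 nM, which is a limit and not a number, so its steps from compound 1, compound 2 and compound 3 cannot be read. The series now shows only one result: the limit of > 100000 nM in this assay, at which 4 of the 4 values shown sit. The compounds shown leave open at what concentration any of them would become cytotoxic, and whether the different groups on that nitrogen change this concentration.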